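Bulk at the Chain End of an Aminoquinoline Ether

The source may report more compounds than this note shows. Statements on the series, on what has been measured and on what is new or still open speak of the compounds shown alone.

Three compounds share one core and differ only in the group attached to the ring oxygen. Compound 1 `CC(C)Oc1cccc2ccc(N)nc12` gives 437 nM in an assay on cells with melanin-concentrating hormone receptor 1 (Homo sapiens) as the target, read by radioligand binding; on this read-out higher numbers stand for weaker inhibition and lower numbers for stronger inhibition. Compound 2 `CC(C)C(C)Oc1cccc2ccc(N)nc12` gives 199 nM and compound 3 `CCCOc1cccc2ccc(N)nc12` gives 1100 nM in this assay. Compound 3 thus sits at the weak end of the three: it is a 2.5-fold higher number from compound 1 to compound 3 (0.40 log units; beyond the scatter) and a 5.5-fold higher number from compound 2 to compound 3 (0.74 log units; beyond the scatter).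

Compound 4 `CC(C)(C)CCOc1cccc2ccc(N)nc12` differs from compound 3 as follows: tert-butyl in place of methyl on a saturated chain carbon, two bonds along the chain from an oxygen on an aromatic ring. The measured steps all concern branching near the oxygen rather than at the far end of the chain. There, adding bulk helped, seen as a 2.2-fold lower number from compound 1 to compound 2 (0.34 log units; beyond the scatter), while straightening the chain hurt, seen as the steps from compound 1 and compound 2 to compound 3 already given. Among the compounds with values here, no measured step tests branching two bonds out, so the bearing of these steps is indirect, and only a modest gain is expected.

Compound 4 is therefore expected to give about 500 nM in this assay, with a likely range from 200 nM to 1500 nM. This estimate corresponds to an expected 2.2-fold lower number from compound 3 to compound 4 (0.34 log units; beyond the scatter).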

Compound 4, half-maximal inhibitory concentration: 201 nM
Compound 4: the middle estimate sits 2.5-fold (0.40 log units) above what was measured, and the stated range covers the measured number.
By their numbers in this assay, from the lowest: compounds 2 and 4 (each within the scatter of the next); then compound 1; then compound 3.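

In this assay, the far end of the chain matters too: tert-butyl in place of methyl, two bonds along the chain from the oxygen, gives a clear change (a 5.5-fold lower number from compound 3 to compound 4 (0.74 log units; beyond the scatter)), so gains in this small set are not confined to branching near the oxygen. The 3,3-dimethylbutyl group cannot be told apart from the 1,2-dimethylpropyl group (a 1.0-fold higher number from compound 2 to compound 4 (0.00 log units; within the scatter)), and it also does better than isopropyl (a 2.2-fold lower number from compound 1 to compound 4 (0.34 log units; beyond the scatter)), something the propyl chain of compound 3 did not do. Nothing available here explains why bulk at these two different places gives values within the scatter of each other.

Going by these compounds, it remains open whether the gain in compound 4 depends on the tert-butyl branching itself or mainly on the greater length of the group, a question that a straight pentyl chain on the same oxygen would help settle. Also open, on these data alone, is how a cyclohexyl ring, an amine or a carboxylic acid at the same chain end would compare with tert-butyl.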